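A Methyl on an Aromatic Nitrogen: Expected Lipophilicity Shift

The source may hold more compounds than are shown below. What is called first, only, known or untested is meant among the compounds shown, and "the series" means these compounds.

Of the compounds shown here, three have been measured in a physicochemical assay for lipophilicity, read by HPLC, measured as octanol-water partition, at pH 11; on this read-out higher numbers stand for higher lipophilicity and lower numbers for lower lipophilicity. Compound 1 `O=C(NCCO)c1ccc2ccc(C(=O)c3ccccc3)c-2cc1` gives 2.2, compound 3 `CN(C)C(=O)c1ccc2cccccc1-2` gives 1.6, and compound 2 `NC(=O)C1CCN(C(=O)c2c[nH]c3ccccc23)CC1` gives -0.2. Compound 2 thus stands lowest of the three; compound 3 is nearest to it and compound 1 furthest, and both of those gaps lie beyond the usual scatter of this assay. Compound 4 `Cn1cc(C(=O)N2CCC(C(N)=O)CC2)c2ccccc21` has not yet been measured. It differs from compound 2 in one place: methyl in place of hydrogen on an aromatic nitrogen. Starting from the value of compound 2 in this assay, a small upward step is expected: a number 0.50 log units higher from compound 2 to compound 4 (beyond the scatter) is estimated to lie just beyond the scatter, in the direction of higher lipophilicity. Compound 4 is therefore expected to give about 0.3, most likely between -0.1 and 0.7.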

Compound 4, distribution coefficient: 0.4
Compound 4: the middle estimate sits 0.10 log units below what was measured; the range from low to high includes it.
By their numbers in this assay, from the lowest: compound 2; then compound 4; then compound 3; then compound 1.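

Within the data shown here, the earlier compounds held no pair differing in one place, so this is the first change at this position that can be read on its own: in this assay methyl in place of hydrogen on an aromatic nitrogen brings a number 0.60 log units higher from compound 2 to compound 4 (beyond the scatter) and nothing else in the structure changes. The step is modest and rests on this one pair. Nothing at hand explains the shift.

Going by these compounds, whether an ethyl group or a longer chain ending in an amine on the same nitrogen would move the number further, or in the same direction, stays open. So does whether methyl would give a similar step on another core.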